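Shortening the alkenyl chain on the core nitrogen

The compounds below may be only part of what the source reports. "The series", "measured", "known", "first", "only" and "open" are said of these compounds alone.

Compound 1 `CC/C=C\Cn1c(Cc2cc(OC)c(OC)c(OC)c2)nc2c(N)ncnc21` in a functional assay on MCF7 cells (Homo sapiens) for antiproliferative activity (on this read-out lower numbers stand for stronger inhibition and higher numbers for weaker inhibition), gives 64600 nM. Compound 2 `C=CCCn1c(Cc2cc(OC)c(OC)c(OC)c2)nc2c(N)nc(F)nc21` in this assay gives 33100 nM, so compound 1 stands alongside compound 2, the two values lying within the scatter of each other. Compound 3 `C/C=C/Cn1c(Cc2cc(OC)c(OC)c(OC)c2)nc2c(N)ncnc21` carries the change (prop-1-en-1-yl in place of but-1-en-1-yl on a saturated chain carbon bound to an aromatic nitrogen). For the measured compounds named here, no measured pair shows the effect of such a shortening, so the step of a 1.1-fold lower number from compound 1 to compound 3 (0.03 log units; within the scatter) is expected to stay within the scatter, with no clear direction. Compound 3 in this assay is estimated at 60000 nM, within a range of 20000 nM to 180000 nM.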

Compound 3, half-maximal inhibitory concentration: 51300 nM
The estimate for compound 3 lay 1.2-fold (0.07 log units) above the measured number, within the range that was stated.
By their numbers in this assay, from the lowest: compounds 2, 3 and 1 (each within the scatter of the next).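

Shortening but-1-en-1-yl to prop-1-en-1-yl on a saturated chain carbon bound to an aromatic nitrogen gives the first comparison at this position that differs in one place. In this assay this change stays within the scatter (a 1.3-fold lower number from compound 1 to compound 3 (0.10 log units; within the scatter)), so it shows no clear direction. Across these two alkenyl chains, the read-out does not separate the shorter group from the longer one.

Still open, going by these compounds, is whether a longer chain, a cyclopropylmethyl group or an amine at this position would move the number beyond the scatter. No measurement at hand explains the result.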